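Dropping One Hydroxy Group: What to Expect for Cytotoxicity

A few compounds are considered here, and "the series" means these few. Any claim that something is new, unique, unknown or untested is made for them only; others in the source may bear on it.

Measured so far in a functional assay on A549 cells (Homo sapiens) for cytotoxicity, read by sulforhodamine B assay; on this read-out lower numbers stand for stronger inhibition and higher numbers for weaker inhibition:
compound 1 `COc1cc(-c2ccccc2)cc(O)c1O`: > 10000 nM
compound 2 `COc1cc(-c2ccccc2)cc(OC)c1OC`: > 10000 nM
compound 3 `COc1cc(OC)cc(-c2ccccc2O)c1`: > 10000 nM

Each of these three values is a limit of the assay rather than a number. Compound 1 gives > 10000 nM in this assay, a limit. Compound 2 gives > 10000 nM there, also a limit. Compound 3 gives > 10000 nM, again a limit. Compound 1 therefore stands at the same limit as the other two, and nothing separates them: the limit of > 10000 nM in this assay, at which 3 of the 3 values shown sit. For the measured compounds named here, no pair of measured compounds differs in a single place, so no step size can be read from the data.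

Compound 4 `COc1cc(O)cc(-c2ccccc2)c1` has not yet been measured. It differs from compound 1 by one change: hydrogen in place of hydroxy on an aromatic carbon. Going by the values given here, since every value so far sits at the limit, no direction or size of step can be derived; the expectation is that compound 4 also stays at or near the limit, with no step beyond the scatter expected in this assay. Compound 4 is expected at 15000 nM, in a range from 5000 nM to 50000 nM. This estimate implies an expected step that the limit leaves unreadable from compound 1 to compound 4.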

Compound 4, half-maximal inhibitory concentration: > 10000 nM
Compound 4 gave a limit, no number; the forecaster's own chance of this, stated with the estimate: 85%; the middle value lies beyond the limit too.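

Compound 1 and compound 4 both give a limit rather than a number, so no step can be read for hydrogen in place of hydroxy: the limit of > 10000 nM in this assay, at which 4 of the 4 values shown sit.

The compounds shown leave open whether this change on an aromatic carbon alters cytotoxicity at all.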